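Triazole N-substituent swap on two furopyrimidinone cores

A few compounds are considered here, and "the series" means these few. Any claim that something is new, unique, unknown or untested is made for them only; others in the source may bear on it.

Measured so far:
compound 1 `CCCCCCC#Cc1c(CCCCCC)oc2nc(=O)n(Cc3cn(-c4ccc(Cl)cc4)nn3)cc12` — > 100000 nM
compound 2 `CCCCCCC#Cc1c(CCCCCC)oc2nc(=O)n(Cc3cn(Cc4ccccc4)nn3)cc12` — 27300 nM
compound 3 `O=c1nc2oc(CCCCl)cc2cn1Cc1cn(Cc2ccccc2)nn1` — 23500 nM

In a functional assay on CFPAC-1 cells (Homo sapiens) for antiproliferative activity, read by MTT assay, with a stated time of 72 h (a higher number here means a weaker inhibitor, a lower number a stronger inhibitor), compound 1 gives > 100000 nM, which is a limit of the assay and not a number. In this assay compound 2 gives 27300 nM and compound 3 gives 23500 nM; these two values sit within the scatter of each other. The cores of compound 2 and compound 3 differ in the alkyne-bearing furan substitution pattern, and the difference between the two cores is not broken down here.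

One change is observed once and is now to be repeated. From compound 2 to compound 1 it reads (4-chlorophenyl in place of benzyl on an aromatic nitrogen). Its effect is an at least 3.6-fold higher number from compound 2 to compound 1 (0.56 log units; beyond the scatter), with the end point resting on (the limit of > 100000 nM in this assay, at which 1 of the 3 values shown sits).

Compound 4 `O=c1nc2oc(CCCCl)cc2cn1Cc1cn(-c2ccc(Cl)cc2)nn1` is not yet measured. It differs from compound 3 by 4-chlorophenyl in place of benzyl on an aromatic nitrogen, the same change at the same place as from compound 2 to compound 1. On the core of compound 3 the same weakening is expected, so that a 3.8-fold higher number from compound 3 to compound 4 (0.58 log units; beyond the scatter) is the estimated step, resting on an at least 3.6-fold higher number from compound 2 to compound 1 (0.56 log units; beyond the scatter) and the near-equal starting points of compound 2 and compound 3. Compound 4 is therefore estimated at 90000 nM, with a plausible span from 40000 nM to 200000 nM, and a sizable chance that this assay again reports only a limit.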

Compound 4, half-maximal inhibitory concentration: > 100000 nM
Compound 4: only a limit was reported (the forecaster's own chance of this, stated with the estimate: 55%); middle value at least 1.1-fold (0.04 log units) away from the limit.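

In this assay compound 4 gives > 100000 nM, which is a limit of the assay and not a number. The step reads an at least 4.2-fold higher number from compound 3 to compound 4 (0.62 log units; beyond the scatter), so 4-chlorophenyl in place of benzyl on the aromatic nitrogen gives a higher number on both cores, and the direction of the change carries from one core to the other in these two pairs: the same change on two cores in this assay, an at least 3.6-fold higher number (0.56 log units; beyond the scatter) from compound 2 to compound 1 and an at least 4.2-fold higher number (0.62 log units; beyond the scatter) from compound 3 to compound 4; the limit leaves it open whether they differ Neither the full size of the step on either core nor any difference between the cores can be read, so these pairs show a shared direction and a lower bound, not an equal effect: the limit of > 100000 nM in this assay, at which 2 of the 4 values shown sit.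

The compounds shown leave open whether the weakening goes with the chlorine or with the exchange of benzyl for a ring set directly on the nitrogen, a question that a plain phenyl and a 4-chlorobenzyl on the same aromatic nitrogen would separate. Also open, on these data alone, is whether the change carries to a third core, for instance one with an amine or a carboxylic acid on its side chain, and whether any aryl group on this nitrogen gives a number clear of the limit.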